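This account rests on a few compounds, and the source may have more. Where it says the series, first, only, none or still open, it means among the compounds named here.

Compound 1 `CCN(CCCOc1ccc(C(=O)/C=C/c2ccc(N(C)C)cc2)c(O)c1)Cc1ccc(N(C)C)cc1` and compound 2 `CCN(CCCOc1ccc(C(=O)/C=C/c2ccccc2)c(O)c1)Cc1ccccc1N(C)C` share one core and have both been tested in an assay on isolated protein for inhibition of Amine oxidase [flavin-containing] A (Homo sapiens); on this read-out higher numbers stand for weaker inhibition and lower numbers for stronger inhibition. In this assay compound 1 gives 57500 nM, and compound 2 gives 67800 nM. Of these two numbers, compound 2 shows the higher one, yet its gap to compound 1 lies within the scatter, so the two cannot be told apart. The two differ from each other in more than one place, so no single structural change can be read off from their pair.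

Compound 3 `CCN(CCCOc1ccc(C(=O)/C=C/c2ccc(N(C)C)cc2)c(O)c1)Cc1ccccc1N(C)C` has not yet been measured. It differs from compound 2 in one place only: dimethylamino in place of hydrogen on an aromatic carbon. Compound 1 carries the same dimethylamino at the same place and nonetheless gives 57500 nM. In this assay the expected change is a 1.1-fold lower number from compound 2 to compound 3 (0.05 log units; within the scatter), which amounts to nothing beyond the scatter. Compound 3 is therefore estimated at 60000 nM, within a range from 25000 nM to 150000 nM.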

Compound 3, half-maximal inhibitory concentration: 23600 nM
Compound 3: middle estimate off by 2.5-fold (0.41 log units), on the high side, outside the stated range (below it).
By their numbers in this assay, from the lowest: compound 3; then compounds 1 and 2 (each within the scatter of the next).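

In this assay the change from 2-phenylethenyl to 2-(4-(dimethylamino)phenyl)ethenyl makes a measurable difference, with a 2.9-fold lower number from compound 2 to compound 3 (0.46 log units; beyond the scatter) as a modest step. The other place on the shared core also counts, since 2-(dimethylamino)phenyl in place of 4-(dimethylamino)phenyl on the saturated chain carbon bound to the amine nitrogen gives a 2.4-fold lower number from compound 1 to compound 3 (0.39 log units; beyond the scatter) as a second modest step, something the earlier pair could not show with its two compounds differing in more than one place. Nothing at hand explains why either change lowers the number.

From the compounds shown here alone, it remains open whether dimethylamino is special on the 2-phenylethenyl side, or whether a methoxy group or a plain amine at the same place would give a step of similar size. On the other side, it is also unknown how a longer chain in place of the ethyl group on the amine nitrogen, or a carboxylic acid on the same ring as the 2-(dimethylamino) group, would shift the number.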